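Trimming the amide side chain to a bare hydroxy group

The compounds below may be only part of what the source reports. "The series", "measured", "known", "first", "only" and "open" are said of these compounds alone.

Measured so far:
- Compound 1 `Cc1ccc(OCC(=O)N(CCCO)Cc2cccs2)cc1`: 3000 nM
- Compound 2 `CCN(Cc1nccs1)C(=O)COc1ccc(C)cc1`: 3060 nM

In an assay on HEK293 cells for agonist activity at transient receptor potential cation channel subfamily M member 8 (Homo sapiens), read by fluorescence and calcium flux, with a stated time of 15 min (on this read-out lower numbers stand for an effect already at smaller amounts and higher numbers for an effect only at larger amounts of compound), compound 1 gives 3000 nM, and compound 2 gives 3060 nM; the two numbers lie within the usual scatter of each other, so neither can be set apart. Compound 3 `Cc1ccc(OCC(=O)N(O)Cc2cccs2)cc1` has not been measured. It differs from compound 1 by hydroxy in place of 3-hydroxypropyl on an amide-type nitrogen. Within the data shown here, no measured pair shows the effect of this change, so a step of modest size in either direction, or none beyond the scatter, is possible. Compound 3 is expected to give 4500 nM, in a range from 1200 nM to 15000 nM, which would mean an estimated step of a 1.5-fold higher number from compound 1 to compound 3 (0.18 log units; within the scatter).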

Compound 3, half-maximal effective concentration: 8000 nM
Estimate against measurement, compound 3: 1.8-fold (0.25 log units) below; measured number inside the range.
By their numbers in this assay, from the lowest: compounds 1 and 2 (each within the scatter of the next); then compound 3.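

In this assay hydroxy in place of 3-hydroxypropyl on an amide-type nitrogen gives a 2.7-fold higher number from compound 1 to compound 3 (0.43 log units; beyond the scatter) and so shows that the number responds to the group at this position. The two groups have matching counts of hydrogen-bond donors and acceptors, so the step goes with the smaller group and not with a difference in those counts. Nothing available explains the step. From the compounds shown here alone, whether a plain propyl chain, a 2-hydroxyethyl chain or a chain ending in an amine would give a lower or higher number remains open.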